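The compounds below may be only part of what the source reports. "The series", "measured", "known", "first", "only" and "open" are said of these compounds alone.

Working notes on the series. Compound 1 `COc1ccc(C(O)(Cc2ccc(C)cc2)c2cccc3ccccc23)c(OC)c1OC` gives, in a functional assay on THP-1 cells (Homo sapiens) for inhibition, read by sulforhodamine B assay, with a stated time of 48 h (on this read-out higher numbers stand for weaker inhibition and lower numbers for stronger inhibition), a value of > 20000 nM, which is a limit of the assay and not a number. Compound 3 `COc1ccc(/C(=C/c2ccc(F)cc2)c2cccc3ccccc23)c(OC)c1OC` gives 18900 nM in this assay. Compound 2 `COc1ccc(C(c2ccccc2O)c2cccc3ccccc23)c(OC)c1OC` likewise returns only a limit in this assay, > 20000 nM. Two of the three values shown sit at that limit (the limit of > 20000 nM in this assay, at which 2 of the 3 values shown sit). Compound 4 `COc1ccc(C(c2ccc(OCC(=O)O)cc2)c2cccc3ccccc23)c(OC)c1OC` has not been measured; it differs from compound 2 in one place: 4-(carboxymethoxy)phenyl in place of 2-hydroxyphenyl on a saturated chain carbon bound to two aromatic carbons. Within the data shown here, no step between measured compounds is available, so nothing tells how large such a change is. Compound 2 stands at a limit, so the direction is open. A step of a number no higher from compound 2 to compound 4 (the limit leaves the size open) is expected, within the scatter. Compound 4 is estimated at 20000 nM, range 8000 nM to 50000 nM, with a fair chance of another limit.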

Compound 4, half-maximal inhibitory concentration: > 20000 nM
Compound 4: no number, only a limit (the forecaster's own chance of this, stated with the estimate: 55%); the middle value lies on the limit itself.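

Compound 4 returns only a limit, > 20000 nM, which is not a number, so no step can be read between compound 2 and compound 4. The compounds shown leave open whether 4-(carboxymethoxy)phenyl in place of 2-hydroxyphenyl changes inhibition at all: the limit of > 20000 nM in this assay, at which 3 of the 4 values shown sit.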